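Vinyl for Iodo in a Cytotoxicity Screen

This account rests on a few compounds, and the source may have more. Where it says the series, first, only, none or still open, it means among the compounds named here.

Compound 2 `Ic1nc2ccccc2s1` carries an iodo group on the shared core. In a functional assay on HCT-116 cells (Homo sapiens) for cytotoxicity, with a stated time of 3 days (on this read-out higher numbers stand for weaker inhibition and lower numbers for stronger inhibition), compound 2 returns only the limit > 40000 nM. Compound 1 `C=Cc1nc2ccccc2s1` carries vinyl in its place, the change being (vinyl in place of iodo on an aromatic carbon). In this assay compound 1 likewise returns only the limit > 40000 nM. The resulting step that the two limits leave unreadable from compound 2 to compound 1 cannot be read. Compound 3 `Ic1nc2ccccc2o1` is the iodo member of a second core; the difference between the two cores is not broken down here. In this assay compound 3 gives only the limit > 40000 nM. Compound 4 `C=Cc1nc2ccccc2o1` is not yet measured; it differs from compound 3 by vinyl in place of iodo on an aromatic carbon, the same kind of change as before, here next to the ring oxygen rather than next to the ring sulfur. For the measured compounds named here, the step of a number no higher from compound 3 to compound 4 (the limit leaves the size open) is expected to stay unreadable because the limit of > 40000 nM in this assay, at which 3 of the 3 values shown sit, holds every value so far. Compound 4 is estimated at 40000 nM, most probably again as a limit, between 15000 nM and 40000 nM.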

Compound 4, half-maximal inhibitory concentration: > 40000 nM
Compound 4 ended at the assay's limit (the forecaster's own chance of this, stated with the estimate: 85%); the middle value lies on the limit itself.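

No new step can be read between compound 3 and compound 4, as both stand at a limit: the limit of > 40000 nM in this assay, at which 4 of the 4 values shown sit.

The compounds shown leave open how vinyl and iodo, or the two cores, compare in this assay.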